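This account rests on a few compounds, and the source may have more. Where it says the series, first, only, none or still open, it means among the compounds named here.

Measured compounds:

compound 1 `N[C@@H](CC1CCCCC1)CN(C(=O)[C@@H]1C[C@H]1c1ccccc1)c1ccc(-c2ccccc2)cc1`: 1.7 nM
compound 2 `CCC(C)CNCCN(C(=O)[C@@H]1C[C@H]1c1ccccc1)c1ccc(-c2ccccc2)cc1`: 4.7 nM
compound 3 `CC[C@H](C)[C@H](N)CN(C(=O)[C@@H]1C[C@H]1c1cccc(C#N)c1)c1ccc(-c2ccccc2)cc1`: 1600 nM

For the measured compounds named here, in a functional assay for agonist activity at G protein-coupled receptor 88 (Homo sapiens), read by HTRF and cAMP accumulation (a lower number here means that less compound is needed, a higher number that more compound is needed for the effect), compound 1 gives 1.7 nM and compound 2 gives 4.7 nM; the one measured step between them, a 2.8-fold higher number from compound 1 to compound 2 (0.44 log units; beyond the scatter), concerns the chain on the amide nitrogen and not the ring on the cyclopropane. Compound 3 gives 1600 nM in this assay, the highest number of the three and far above both others.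

Compound 4 `CC[C@H](C)[C@H](N)CN(C(=O)[C@@H]1C[C@H]1c1ccsc1)c1ccc(-c2ccccc2)cc1` differs from compound 3 at the cyclopropane: thiophen-3-yl in place of 3-cyanophenyl on a saturated ring carbon. Going by the values given here, no measured step covers a change at this position, so the only guidance is that compound 3 stands far higher in this assay than compounds 1 and 2, which carry plain phenyl there but also differ elsewhere. The expectation is therefore cautious: compound 4 is estimated to give 600 nM in this assay, within 100 nM to 3500 nM. This corresponds to an expected 2.7-fold lower number from compound 3 to compound 4 (0.43 log units; beyond the scatter), a step that may yet fall within the scatter.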

Compound 4, half-maximal effective concentration: 450 nM
For compound 4 the middle estimate is 1.3-fold (0.12 log units) above the measured one, and the stated range covers the measured number.
By their numbers in this assay, from the lowest: compound 1; then compound 2; then compound 4; then compound 3.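

For the compounds shown here, this is the first measured change at the cyclopropane: in this assay, thiophen-3-yl in place of 3-cyanophenyl gives a 3.6-fold lower number from compound 3 to compound 4 (0.55 log units; beyond the scatter) while the rest of the molecule stays the same, so the group on this saturated ring carbon can move the number beyond the scatter. The swap replaces a six-membered aromatic ring of carbon only, carrying a nitrile, with a five-membered aromatic ring containing sulfur, so the change of ring and the loss of the nitrile cannot be told apart. No measurement at hand explains the direction of this step.

Plain phenyl appears only with other chains on the amide nitrogen, so its standing with the chain of compound 3 and compound 4 remains open. So does the effect of a thiophen-2-yl or pyridin-3-yl group at this position.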